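This account rests on a few compounds, and the source may have more. Where it says the series, first, only, none or still open, it means among the compounds named here.

Measured compounds:
compound 1, `COCCN(C)S(=O)(=O)c1ccc(C)c(C#Cc2cc(Cl)ccc2OCC(=O)O)c1`, 4.1 nM
compound 2, `Cc1ccc(S(=O)(=O)Cc2ccccc2)cc1C#Cc1cc(Cl)ccc1OCC(=O)O`, 5 nM
compound 3, `Cc1ccc(S(=O)(=O)N2CCCCC2C)cc1C#Cc1cc(Cl)ccc1OCC(=O)O`, 1.9 nM

All three were tested in an assay on CHO cells for displacement of a labelled ligand from prostaglandin D2 receptor 2 (Homo sapiens), read by scintillation counting; on this read-out lower numbers stand for stronger inhibition and higher numbers for weaker inhibition. Compound 3 gives the lowest of the three numbers in this assay; it stands a 2.2-fold lower number from compound 1 to compound 3 (0.33 log units; beyond the scatter) and a 2.6-fold lower number from compound 2 to compound 3 (0.42 log units; beyond the scatter), both steps modest but beyond the scatter, while the two other compounds sit within the scatter of each other, a 1.2-fold higher number from compound 1 to compound 2 (0.09 log units; within the scatter).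

Compound 4, `Cc1ccc(S(=O)(=O)CC(C)C)cc1C#Cc1cc(Cl)ccc1OCC(=O)O`, has not yet been measured. It differs from compound 3 in one place: isobutyl in place of 2-methylpiperidin-1-yl on a sulfonyl sulfur. Every measured step in this series changes the group on the same sulfonyl sulfur, so all three bear on it. Leaving the 2-methylpiperidin-1-yl group for either of the other two groups raised the number modestly, and the two acyclic or carbon-attached alternatives did not differ beyond the scatter. Isobutyl is another acyclic, carbon-attached group with no ring, so a modest rise in the number is expected for compound 4, a 2.4-fold higher number from compound 3 to compound 4 (0.37 log units; beyond the scatter). Compound 4 is therefore estimated at 4.5 nM in this assay, with a range from 2 nM to 10 nM.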

Compound 4, inhibition constant: 3 nM
Beside the measured number, compound 4's estimate is 1.5-fold (0.18 log units) above it; the range from low to high includes it.
By their numbers in this assay, from the lowest: compounds 3, 4, 1 and 2 (each within the scatter of the next, the first and the last beyond it).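

In this assay, isobutyl on the sulfonyl sulfur cannot be separated from 2-methylpiperidin-1-yl (a 1.6-fold higher number from compound 3 to compound 4 (0.20 log units; within the scatter)), so on these numbers neither the ring nor a nitrogen on the sulfonyl sulfur is required to stay in the same range. Compound 4 also stays within the scatter of the benzyl group (a 1.7-fold lower number from compound 2 to compound 4 (0.22 log units; within the scatter)) and the (2-methoxyethyl)(methyl)amino group (a 1.4-fold lower number from compound 1 to compound 4 (0.14 log units; within the scatter)), so it bridges the two modest gaps that had set compound 3 apart from compound 1 and compound 2. No measurement is available that would explain these results.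

The compounds shown leave open how far the sulfonyl substituent can shrink or grow, as with a methyl group or a longer chain such as n-hexyl. They also leave open whether unsubstituted piperidine or morpholine would behave like 2-methylpiperidin-1-yl.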